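Oxadiazole in Place of Amide on the Sulfinyl Chain

The compounds below may be only part of what the source reports. "The series", "measured", "known", "first", "only" and "open" are said of these compounds alone.

Three compounds share one core and differ only in the group carried on a saturated chain carbon bound to a sulfur. In an assay on isolated protein for inhibition of Norepinephrine transporter (Rattus norvegicus), read by radioligand binding (on this read-out lower numbers stand for stronger inhibition and higher numbers for weaker inhibition), compound 1 `COC(=O)C[S+]([O-])CC1CN(C)CCC1c1ccc(Cl)cc1` gives 53 nM, compound 2 `CC(=O)OCC[S+]([O-])CC1CN(C)CCC1c1ccc(Cl)cc1` gives 29 nM, and compound 3 `CNC(=O)C[S+]([O-])CC1CN(C)CCC1c1ccc(Cl)cc1` gives 86 nM. Compound 3 has the highest number of the three: a 1.6-fold higher number from compound 1 to compound 3 (0.21 log units; within the scatter), whereas a 3.0-fold higher number from compound 2 to compound 3 (0.47 log units; beyond the scatter). The remaining step, a 1.8-fold lower number from compound 1 to compound 2 (0.26 log units; within the scatter), separates the other two.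

Compound 4 `Cc1noc(C[S+]([O-])CC2CN(C)CCC2c2ccc(Cl)cc2)n1` is obtained from compound 3 by the change (3-methyl-1,2,4-oxadiazol-5-yl in place of methylcarbamoyl on a saturated chain carbon bound to a sulfur). Among the measured compounds shown here, no measured step introduces an aromatic ring at this position, so only indirect guidance exists. The step of a 3.0-fold higher number from compound 2 to compound 3 (0.47 log units; beyond the scatter) shows that exchanging the group on this carbon can move the number modestly, and the step of a 1.6-fold higher number from compound 1 to compound 3 (0.21 log units; within the scatter) shows a smaller move when the carbonyl bears methylamino instead of methoxy. Because compound 1 gives 53 nM and compound 2 gives 29 nM, compound 4 is expected to move toward their numbers, by an estimated step of a 2.2-fold lower number from compound 3 to compound 4 (0.33 log units; beyond the scatter). Compound 4 is therefore estimated at 40 nM, with an expected range from 12 nM to 130 nM.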

Compound 4, inhibition constant: 218 nM
For compound 4 the middle estimate is 5.5-fold (0.74 log units) below the measured one, outside the stated range (above it).
By their numbers in this assay, from the lowest: compounds 2, 1 and 3 (each within the scatter of the next, the first and the last beyond it); then compound 4.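

In this assay the 3-methyl-1,2,4-oxadiazol-5-yl group on a saturated chain carbon bound to a sulfur stands apart from all three earlier groups, with a 2.5-fold higher number from compound 3 to compound 4 (0.40 log units; beyond the scatter) and a 4.1-fold higher number from compound 1 to compound 4 (0.61 log units; beyond the scatter) and a 7.5-fold higher number from compound 2 to compound 4 (0.88 log units; beyond the scatter) as its steps. The three earlier groups all carry a carbonyl and no ring, and the widest step among them, a 3.0-fold higher number from compound 2 to compound 3 (0.47 log units; beyond the scatter) and so beyond the scatter, is smaller than the widest step that compound 4 opens. So this position does not treat the aromatic ring as an equal exchange for methylcarbamoyl, and compound 4 is the weakest of the four on this read-out, since its steps to the other three all lie beyond the scatter.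

Whether the rise follows the five-membered ring itself or the methyl group on it stays open, since compound 4 is the only compound shown with a ring at this place. Going by these compounds, how a phenyl ring, a carboxylic acid or a longer chain would read on this carbon is equally open.

Nothing given here bears on why the number rises with this change.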